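A Benzofuran Replaces the Methoxyphenyl Arm

This account rests on a few compounds, and the source may have more. Where it says the series, first, only, none or still open, it means among the compounds named here.

Compound 1 `C/C(=N\Nc1nc(-c2ccc(Br)cc2)cs1)c1cc2ccccc2o1`, compound 2 `C/C(=N\Nc1nc(-c2ccc(Cl)cc2)cs1)c1cc2ccccc2o1` and compound 3 `COc1ccc(-c2csc(N/N=C(\C)c3cc4ccccc4o3)n2)cc1` share one core and differ only in a single substituent. In a functional assay on HepG2 cells (Homo sapiens) for antiproliferative activity (a higher number here means a weaker inhibitor, a lower number a stronger inhibitor), compound 1 gives 27700 nM, compound 2 gives 23200 nM and compound 3 gives 15700 nM. The three are close: a 1.2-fold lower number from compound 1 to compound 2 (0.08 log units; within the scatter), a 1.8-fold lower number from compound 1 to compound 3 (0.25 log units; within the scatter) and a 1.5-fold lower number from compound 2 to compound 3 (0.17 log units; within the scatter). Compound 3 thus has the lowest of the three numbers, yet its gap to compound 2 and to compound 1 is within the scatter, so no ordering among them can be claimed.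

Compound 4 `C/C(=N\Nc1nc(-c2cc3ccccc3o2)cs1)c1cc2ccccc2o1` is not yet measured. It differs from compound 3 in one place: 1-benzofuran-2-yl in place of 4-methoxyphenyl on an aromatic carbon. This change is of a different kind from the three measured steps, each of which swapped one small substituent for another and each of which stayed within the scatter. Within the data shown here, no measured step therefore bears directly on exchanging the whole 4-methoxyphenyl for 1-benzofuran-2-yl, and the only guide is that every change tried so far on the same aromatic carbon left this assay essentially unmoved. On that basis the expected step is a 1.0-fold lower number from compound 3 to compound 4 (0.02 log units; within the scatter), none beyond the scatter in either direction. The value of compound 4 in this assay is estimated at 15000 nM, with a range from 5000 nM to 45000 nM. The range is wide: nothing measured tests this kind of change.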

Compound 4, half-maximal inhibitory concentration: 21300 nM
The estimate for compound 4 lay 1.4-fold (0.15 log units) below the measured number; the measured number falls inside the stated range.
By their numbers in this assay, from the lowest: compounds 3, 4, 2 and 1 (each within the scatter of the next).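

Exchanging the whole 4-methoxyphenyl for 1-benzofuran-2-yl, on the aromatic carbon next to the ring nitrogen, gives in this assay a 1.4-fold higher number from compound 3 to compound 4 (0.13 log units; within the scatter), so the insensitivity seen so far now extends beyond swaps of a small substituent to replacement of the entire group on this carbon. The same holds against the two halogen-bearing groups: 1-benzofuran-2-yl in place of 4-chlorophenyl gives a 1.1-fold lower number from compound 2 to compound 4 (0.04 log units; within the scatter), and in place of 4-bromophenyl it gives a 1.3-fold lower number from compound 1 to compound 4 (0.11 log units; within the scatter), so a group carrying a five-membered aromatic ring with 1 hetero atom as well as a six-membered ring of carbon only cannot be told apart from the three groups with a single six-membered ring, and no ordering of the four compounds can be claimed. No independent data are available to explain why these four numbers stay so close.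

Going by these compounds, it remains open whether a group of another kind on this carbon, such as an aminomethyl group, a carboxylic acid or a small methyl, would give a step beyond the scatter. The 1-benzofuran-2-yl arm on the other side of the shared core is also common to compounds 1, 2 and 3 and to compound 4, so what an exchange there, for instance for a 4-methoxyphenyl, would do in this assay is not shown.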